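The compounds below may be only part of what the source reports. "The series", "measured", "known", "first", "only" and "open" are said of these compounds alone.

The shared core of compound 1 `COc1cc(-c2nnc3n2NC(c2ccco2)C(C(=O)c2ccc(Br)cc2)S3)cc(OC)c1OC` carries a 4-bromophenyl on its carbonyl carbon. In a functional assay on PC-3 cells (Homo sapiens) for cytotoxicity, read by MTT assay, with a stated time of 48 h (on this read-out higher numbers stand for weaker inhibition and lower numbers for stronger inhibition), compound 1 gives 36400 nM, the highest of the two plain numbers that were obtained. Compound 2 `COc1cc(-c2nnc3n2NC(c2cccs2)C(C(=O)c2ccc(C)cc2)S3)cc(OC)c1OC` differs from compound 1 in two places; in this assay compound 2 gives 5090 nM. Compound 3 `COc1cc(C(=O)C2Sc3nnc(-c4cc(OC)c(OC)c(OC)c4)n3NC2c2cccs2)cc(OC)c1OC` reaches only the limit of > 100000 nM in this assay, so no number is known for it. Going by the values given here, the one single-point step that was measured, an at least 19-fold higher number from compound 2 to compound 3 (1.29 log units; beyond the scatter), shows that the aryl group on the carbonyl carbon can move the result a great deal.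

Compound 4 `COc1cc(-c2nnc3n2NC(c2ccco2)C(C(=O)c2ccc(F)c(F)c2)S3)cc(OC)c1OC` is compound 1 with a different aryl on that same carbon: 3,4-difluorophenyl in place of 4-bromophenyl on a carbonyl carbon. Among the compounds with values here, no measured step swaps one halogenated phenyl for another, so this change gives no firm direction. The value of compound 4 is therefore expected to stay near that of compound 1, as a 1.1-fold higher number from compound 1 to compound 4 (0.04 log units; within the scatter), with a wide range. Compound 4 is estimated at 40000 nM, between 10000 nM and 120000 nM.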

Compound 4, half-maximal inhibitory concentration: 36000 nM
Beside the measured number, compound 4's estimate is 1.1-fold (0.05 log units) above it, within the range that was stated.
By their numbers in this assay, from the lowest: compound 2; then compounds 4 and 1 (each within the scatter of the next). At a limit, above all of these: compound 3.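

Going by these compounds alone, the exchange of one halogenated phenyl for another on the carbonyl carbon gives a 1.0-fold lower number from compound 1 to compound 4 (0.00 log units; within the scatter), the first measured step of this kind. In this assay this position had shown a large change with an at least 19-fold higher number from compound 2 to compound 3 (1.29 log units; beyond the scatter), yet here 3,4-difluorophenyl and 4-bromophenyl cannot be told apart, so not every change of aryl group on this carbon moves the result. Nothing shown explains why these two groups read alike.

As far as these compounds go, it remains open whether a phenyl group carrying an amine or a carboxylic acid on this carbonyl carbon would stay level with compound 1 or shift the result strongly. From the compounds shown here alone, it is also open whether 4-bromophenyl and 3,4-difluorophenyl would still match on a core changed elsewhere.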